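The source may report more compounds than this note shows. Statements on the series, on what has been measured and on what is new or still open speak of the compounds shown alone.

In a functional assay on SW-620 cells (Homo sapiens) for antiproliferative activity, read by sulforhodamine B assay, with a stated time of 48 h (a lower number here means a stronger inhibitor of growth, a higher number a weaker inhibitor of growth), compound 1 (`O=C(NCCCNc1cc(-c2cn(-c3ccccc3)nc2-c2cccc(O)c2)ccn1)Nc1ccc(F)cc1`) gives 6730 nM. Among the compounds with values here, compound 2 (`O=C(NCCCNc1cc(-c2cn(-c3ccccc3)nc2-c2cccc(O)c2)ccn1)Nc1cccc(C(F)(F)F)c1`) gives 8310 nM, so compound 1 stands level with its only measured neighbour, within the scatter. Compound 3 (`COc1cccc(-c2nn(-c3ccccc3)cc2-c2ccnc(NCCCNC(=O)Nc3ccc(F)cc3)c2)c1`) differs from compound 1 by one change, (methyl in place of hydrogen on an oxygen on an aromatic ring), which turns 3-hydroxyphenyl into 3-methoxyphenyl. Within the data shown here, the one measured step, a 1.2-fold higher number from compound 1 to compound 2 (0.09 log units; within the scatter), lies at an amide-type nitrogen and not at this oxygen, so it offers only weak guidance. No step beyond the scatter is therefore expected in this assay, though the data leave this open. The expected step is a 1.0-fold higher number from compound 1 to compound 3 (0.02 log units; within the scatter). For compound 3 the estimated value is 7000 nM, with an expected range of 3000 nM to 20000 nM.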

Compound 3, concentration for total growth inhibition: > 37000 nM
Compound 3 gave a limit, no number (the forecaster's own chance of this, stated with the estimate: 10%); middle value at least 5.2-fold (0.72 log units) from the limit.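

Methyl in place of hydrogen on this oxygen is the first change shown to move the read-out in this assay beyond the scatter, with an at least 5.4-fold higher number from compound 1 to compound 3 (0.74 log units; beyond the scatter). The step at the amide-type nitrogen, a 1.2-fold higher number from compound 1 to compound 2 (0.09 log units; within the scatter), stayed within the scatter, so this oxygen is the more sensitive of the two places shown. For compound 3 the result is a limit and not a number: the limit of > 37000 nM in this assay, at which 1 of the 3 values shown sits.

Only hydroxy and methoxy appear at this place, and the data do not separate losing the hydrogen from adding the methyl. An amino group or a fluorine there remains untested in the compounds shown, as does an ethoxy group.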